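Trifluoromethoxy for trifluoromethyl on the cinnamamide aryl

A few compounds are considered here, and "the series" means these few. Any claim that something is new, unique, unknown or untested is made for them only; others in the source may bear on it.

Measured compounds:
compound 1 `COc1ccc(C(=O)c2cc(OC)c(OC)c(OC)c2)cc1NC(=O)/C=C/c1cc(OC)c(OC)c(OC)c1` gives 3900 nM in a functional assay on PC-3 cells (Homo sapiens) for cytotoxicity, read by MTT assay, with a stated time of 72 h; a higher number here means a weaker inhibitor, a lower number a stronger inhibitor
compound 2 `COc1ccc(/C=C/C(=O)Nc2cc(C(=O)c3cc(OC)c(OC)c(OC)c3)ccc2OC)cc1` gives 11100 nM in this assay
compound 3 `COc1ccc(C(=O)c2cc(OC)c(OC)c(OC)c2)cc1NC(=O)/C=C/c1ccc(C(F)(F)F)cc1` gives 3500 nM in this assay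

Compound 3 holds the lowest number of the three, though compound 1 sits within the scatter of it, and only compound 2 lies beyond, as a 3.2-fold lower number from compound 2 to compound 3 (0.50 log units; beyond the scatter) shows. Compound 4 `COc1ccc(C(=O)c2cc(OC)c(OC)c(OC)c2)cc1NC(=O)/C=C/c1cccc(OC(F)(F)F)c1` differs from compound 3 in one place: 3-(trifluoromethoxy)phenyl in place of 4-(trifluoromethyl)phenyl on a double-bonded chain carbon bound to a double-bonded chain carbon. Two measured steps change the same aryl group. a 1.1-fold lower number from compound 1 to compound 3 (0.05 log units; within the scatter) stayed within the scatter, while a 2.8-fold higher number from compound 1 to compound 2 (0.45 log units; beyond the scatter) was modest. Among the measured compounds shown here, no measured step involves a trifluoromethoxy group, so the evidence is indirect. The aryl swaps seen so far were small, and compound 4 is therefore expected to land near compound 3, with a 1.1-fold higher number from compound 3 to compound 4 (0.06 log units; within the scatter) as the expected step. Compound 4 is estimated at 4000 nM, between 1500 nM and 11000 nM.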

Compound 4, half-maximal inhibitory concentration: 7700 nM
For compound 4 the middle estimate is 1.9-fold (0.28 log units) below the measured one; measured number inside the range.
By their numbers in this assay, from the lowest: compounds 3, 1, 4 and 2 (each within the scatter of the next, the first and the last beyond it).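

In this assay, among the compounds shown here, a 2.2-fold higher number from compound 3 to compound 4 (0.34 log units; beyond the scatter) shows that this position responds to an exchange between two fluorinated aryl groups, which no earlier step could show. Yet the new aryl does not separate from the two methoxylated ones: a 1.4-fold lower number from compound 2 to compound 4 (0.16 log units; within the scatter) and a 2.0-fold higher number from compound 1 to compound 4 (0.30 log units; within the scatter) both stay within the scatter. No measurement at hand bears on why the step arises. The compounds shown leave open whether the group or its place on the ring carries the step, as neither 4-(trifluoromethoxy)phenyl nor 3-(trifluoromethyl)phenyl stands among them. On these data alone, how an aryl bearing an amine or a carboxylic acid would read also stays open.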